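From 4-Fluorobenzyl to 3-(Dimethylamino)propyl on a Shared Core

A few compounds are considered here, and "the series" means these few. Any claim that something is new, unique, unknown or untested is made for them only; others in the source may bear on it.

Three compounds with a shared core have been taken into testing so far. Compound 1 `Nc1cccc(Nc2c(C(=O)NCc3ccc(F)cc3)nc(Br)c3cccnc23)c1` gives 8000 nM in a functional assay on MCF7 cells (Homo sapiens) for cytotoxicity, read by MTT assay, with a stated time of 72 h (on this read-out lower numbers stand for stronger inhibition and higher numbers for weaker inhibition), and is the only one of the three with a number. Compound 2 `C[C@@H](Nc1c(C(=O)NCc2ccc(F)cc2)nc(Br)c2cccnc12)c1ccccc1` stands at "not determined" (no result reported) in this assay with nothing to compare. From the compounds shown here alone, compound 3 `O=C(NCc1ccc(F)cc1)c1nc(Br)c2cccnc2c1NCc1ccc(F)cc1` likewise has no single number, only "not determined" (no result reported) in this assay so its place on the scale remains unknown.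

Still to be tested is compound 4 `CN(C)CCCNc1c(C(=O)NCc2ccc(F)cc2)nc(Br)c2cccnc12` which differs in one side chain. The change runs 2-(dimethylamino)ethyl in place of 4-fluorophenyl on a saturated chain carbon bound to a nitrogen on an aromatic ring and puts 2-(dimethylamino)ethyl in place of 4-fluorophenyl on a saturated chain carbon bound to a nitrogen on an aromatic ring.

For the measured compounds named here, no measured step shows what such a swap does. Going by the values given here, the only anchor is compound 1 at 8000 nM and against that figure a modest step toward stronger inhibition is expected, though on thin evidence. Compound 4 is estimated at 4000 nM with an expected range from 800 nM to 20000 nM in this assay once measured.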

Compound 4, half-maximal inhibitory concentration: 7000 nM
The estimate for compound 4 lay 1.8-fold (0.24 log units) below the measured number; the measured number falls inside the stated range.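

For the compounds shown here, the first number-to-number comparison at this place on the shared core comes from the swap of 3-aminophenyl for 3-(dimethylamino)propyl on a nitrogen on an aromatic ring. In (this assay), this swap gives a 1.1-fold lower number from compound 1 to compound 4 (0.06 log units; within the scatter) and so shows no measurable change. In this one pair, a group with a six-membered aromatic ring and an open chain with no ring therefore give values within the scatter of each other, and no measurement at hand offers an explanation for this result.

From the compounds shown here alone, compound 2 and compound 3 carry no number, so their steps to compound 4 cannot be read, and what 4-fluorobenzyl does at this place stays unknown. Also open, going by these compounds, is how a longer chain, or a carboxylic acid in place of the dimethylamino group, would read here.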